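Aryl versus alkyl ketones in a piperazine carbamate series

A few compounds are considered here, and "the series" means these few. Any claim that something is new, unique, unknown or untested is made for them only; others in the source may bear on it.

Measured so far in an assay on isolated protein for binding affinity to histamine H2 receptor (Homo sapiens); a higher number here means a weaker inhibitor, a lower number a stronger inhibitor:
- compound 1, `CCOC(=O)N1CCN(CCCOc2ccc(C(=O)C3CC3)cc2)CC1`, 79400 nM
- compound 2, `CCOC(=O)N1CCN(CCCOc2ccc(C(=O)CC(C)C)cc2)CC1`, 69200 nM
- compound 3, `CCOC(=O)N1CCN(CCCOc2ccc(C(=O)c3ccc(OC)cc3)cc2)CC1`, 8320 nM

Compound 3 gives the lowest number of the three, with compound 2 and compound 1 both roughly a decade higher. The two informative steps, a 9.5-fold lower number from compound 1 to compound 3 (0.98 log units; beyond the scatter) and an 8.3-fold lower number from compound 2 to compound 3 (0.92 log units; beyond the scatter), both trade an alkyl group on the carbonyl for an aryl one; the alkyl-to-alkyl step a 1.1-fold lower number from compound 1 to compound 2 (0.06 log units; within the scatter) stays within the scatter.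

Compound 4, `CCOC(=O)N1CCN(CCCOc2ccc(C(=O)c3cccc(C)c3)cc2)CC1`, keeps the aryl ketone and changes only the ring: 3-methylphenyl in place of 4-methoxyphenyl on a carbonyl carbon. Among the compounds with values here, no measured step compares one aryl group with another, so the aryl-versus-alkyl steps bear only indirectly. Compound 4 is expected to stay close to compound 3, with a small step of a 1.4-fold higher number from compound 3 to compound 4 (0.16 log units; within the scatter) that is likely within the scatter.

The estimate for compound 4 in this assay is 12000 nM, expected between 4000 nM and 40000 nM.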

Compound 4, inhibition constant: 3720 nM
For compound 4 the middle estimate is 3.2-fold (0.51 log units) above the measured one; measured number below the stated range.
By their numbers in this assay, from the lowest: compound 4; then compound 3; then compounds 2 and 1 (each within the scatter of the next).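

Aryl groups on this carbonyl carbon are not interchangeable in this assay: the one aryl-to-aryl step, a 2.2-fold lower number from compound 3 to compound 4 (0.35 log units; beyond the scatter), lies beyond the scatter. The 4-methoxyphenyl oxygen is not required for binding here, and the aryl-over-alkyl advantage holds with 3-methylphenyl, giving a 19-fold lower number from compound 2 to compound 4 (1.27 log units; beyond the scatter) and a 21-fold lower number from compound 1 to compound 4 (1.33 log units; beyond the scatter). No available evidence accounts for the difference between these aryl groups.

This change alters both the substituent and its ring position at once. 3-Methoxyphenyl and 4-methylphenyl would separate those two contributions.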